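Swapping the aryl group on the hydrazone carbon

The compounds below may be only part of what the source reports. "The series", "measured", "known", "first", "only" and "open" are said of these compounds alone.

Compound 1 `COc1ccc(OC)c(/C=N/NC(=O)Nc2ccc(Oc3ccnc(-c4nncn4CCN(C)C)c3)c(F)c2)c1`: in a functional assay on MKN-45 cells (Homo sapiens) for cytotoxicity, read by MTT assay, with a stated time of 72 h (on this read-out higher numbers stand for weaker inhibition and lower numbers for stronger inhibition), compound 1 gives 1510 nM.
Compound 2 `CN(C)CCn1cnnc1-c1cc(Oc2ccc(NC(=O)N/N=C/c3ccc(O)cc3)cc2F)ccn1`: in this assay compound 2 gives 820 nM.

Within the data shown here, of the two numbers measured so far, compound 2 has the lower one, but its only neighbour is compound 1, and the step of a 1.8-fold lower number from compound 1 to compound 2 (0.27 log units; within the scatter) stays within the scatter, so the two compounds are not truly separated. Compound 3 `CN(C)CCn1cnnc1-c1cc(Oc2ccc(NC(=O)N/N=C/c3ccc(F)cc3Cl)cc2F)ccn1` differs from compound 2 in one place: 2-chloro-4-fluorophenyl in place of 4-hydroxyphenyl on a carbon with a double bond to nitrogen. Among the measured compounds shown here, the single measured step that bears on this change is a 1.8-fold lower number from compound 1 to compound 2 (0.27 log units; within the scatter), which also exchanged the aryl group at this same position and left the number within the scatter. For the measured compounds named here, no measured compound carries a halogenated aryl group at this position, so the expectation rests on that one step alone. The estimated step of a 1.2-fold higher number from compound 2 to compound 3 (0.09 log units; within the scatter) is therefore expected to stay within the scatter. Compound 3 is expected to give about 1000 nM in this assay, with a range from 400 nM to 2500 nM.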

Compound 3, half-maximal inhibitory concentration: 870 nM
Compound 3: the middle estimate sits 1.1-fold (0.06 log units) above what was measured, within the range that was stated.
By their numbers in this assay, from the lowest: compounds 2, 3 and 1 (each within the scatter of the next).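

In this assay, among these compounds, 2-chloro-4-fluorophenyl brings halogens onto this carbon for the first time, yet the number stays within the scatter against both other aryl groups (a 1.1-fold higher number from compound 2 to compound 3 (0.03 log units; within the scatter); a 1.7-fold lower number from compound 1 to compound 3 (0.24 log units; within the scatter)). The swap from 4-hydroxyphenyl also goes from a group with hydrogen-bond donor and acceptor counts to one that has none, and even this leaves compound 2 and compound 3 unseparated, so 2,5-dimethoxyphenyl, 4-hydroxyphenyl and 2-chloro-4-fluorophenyl cannot be told apart at this position. No measurement bearing on this result is available to explain it.

On these data alone, all three groups are substituted phenyl rings, so it stays open whether the number would move with a phenyl ring carrying an amine or a carboxylic acid. A longer alkyl chain in place of the ring is equally untested by these compounds.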